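This account rests on a few compounds, and the source may have more. Where it says the series, first, only, none or still open, it means among the compounds named here.

Working notes on the series. Compound 1 `CCC(C(=O)NCc1ccccc1)N1C(=O)CCC1=O` is the parent; in a functional assay on the whole organism (strain Albino Swiss CD1) with Mus musculus as the target (a higher number here means that more compound is needed for the effect, a lower number that less compound is needed), compound 1 gives 90.3 mg/kg. Compound 2 `CCC(C(=O)NCc1cccc(F)c1)N1C(=O)CCC1=O` carries fluoro in place of hydrogen on an aromatic carbon, and in this assay compound 2 gives 47.4 mg/kg. For the measured compounds named here, the only measured step, a 1.9-fold lower number from compound 1 to compound 2 (0.28 log units; within the scatter), does not reach beyond the scatter, so compound 2 stands as the lower of two numbers without being separable from compound 1.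

The next compound, compound 3 `CCC(C(=O)NCc1cccc(C(F)(F)F)c1)N1C(=O)CCC1=O`, differs from compound 2 by trifluoromethyl in place of fluoro on an aromatic carbon. Going by the values given here, no measured step covers an exchange of fluoro for trifluoromethyl at this place; the step from compound 1 to compound 2 is the only one that touches this aromatic carbon, and it was within the scatter. Nothing in the series therefore points to a step beyond the scatter in this assay in either direction, and the expectation is that compound 3 stays near compound 2.

Compound 3 is expected to give 45 mg/kg in this assay, with a range from 20 mg/kg to 100 mg/kg, which means an expected step of a 1.1-fold lower number from compound 2 to compound 3 (0.02 log units; within the scatter).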

Compound 3, dose for half-maximal effect: 77.4 mg/kg
For compound 3 the middle estimate is 1.7-fold (0.24 log units) below the measured one; low and high end bracket the measured number.
By their numbers in this assay, from the lowest: compounds 2, 3 and 1 (each within the scatter of the next).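

In this assay the exchange of fluoro for trifluoromethyl on this aromatic carbon, which takes the entering group from 1 heavy atom to 4 heavy atoms, gives a 1.6-fold higher number from compound 2 to compound 3 (0.21 log units; within the scatter) and so does not separate the two groups. Trifluoromethyl set directly against hydrogen at the same place gives a 1.2-fold lower number from compound 1 to compound 3 (0.07 log units; within the scatter) and so adds a second substituent that cannot be told apart from the parent, which means that hydrogen, fluoro and trifluoromethyl at this place all lie within the scatter of one another in this assay and none of the three steps singles out a group. Nothing at hand bears on why these numbers fall as they do.

The compounds shown leave open whether any group at this place can move the number beyond the scatter, since an amine, a carboxylic acid, a methoxy group or a longer chain does not appear among them. They also leave open whether these same groups behave alike on the other carbons of the ring, as all the substituted compounds here carry their group at this one place.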